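A Nitrooxy Step Repeated on a Second Core

The source may report more compounds than this note shows. Statements on the series, on what has been measured and on what is new or still open speak of the compounds shown alone.

In a functional assay on the whole organism (strain Sprague-Dawley) for inhibition, with Rattus norvegicus as the target, read by paw edema, with stated times of 30 min and 1 h, at a dose of 80 mg/kg by the oral route (on this read-out lower numbers stand for less inhibition and higher numbers for more inhibition at the one dose given (going by the name of the read-out)), three compounds have been measured. Compound 1 `Cc1nc2ccccc2c(=O)n1NC(=O)NC(C)(C)C` gives 10.4%, and compound 3 `CC(C)(C)NC(=O)Nn1c(CO[N+](=O)[O-])nc2ccccc2c1=O` gives 6.4%. The one difference between them is nitrooxy in place of hydrogen on a saturated chain carbon bound to an aromatic carbon, and the step it made reads a number 4 percentage points lower from compound 1 to compound 3 (within the scatter). Compound 2 `CC(=O)Nc1ccc(S(=O)(=O)Nn2c(C)nc3ccccc3c2=O)cc1` gives 20.8%; it stands highest of the three, as its gaps to compound 1 and to compound 3 both lie beyond the scatter. The difference between the cores of compound 1 and compound 2 is not broken down here.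

Compound 4 `CC(=O)Nc1ccc(S(=O)(=O)Nn2c(CO[N+](=O)[O-])nc3ccccc3c2=O)cc1` has not yet been measured. It differs from compound 2 by nitrooxy in place of hydrogen on a saturated chain carbon bound to an aromatic carbon, the same change that separates compound 1 from compound 3, a change that occurs twice among these compounds. Because the earlier instance gave a number 4 percentage points lower from compound 1 to compound 3 (within the scatter), a step of similar size is expected this time, namely a number 3.8 percentage points lower from compound 2 to compound 4 (within the scatter). In this assay compound 4 is therefore estimated at 17%, with the expected range running from 6% to 28%.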

Compound 4, a percentage reported as inhibition, in the whole organism at one dose (the size of the read-out at that dose, not a potency): 15.2%
Compound 4: middle estimate off by 1.8 percentage points, on the high side, within the range that was stated.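

On the second core, in this assay, the nitrooxy change gives a number 5.6 percentage points lower from compound 2 to compound 4 (within the scatter). Set beside the earlier instance, the two steps agree: the same change on two cores in this assay, a number 4 percentage points lower (within the scatter) from compound 1 to compound 3 and a number 5.6 percentage points lower (within the scatter) from compound 2 to compound 4, 1.6 percentage points apart, within the scatter of two such steps. Carried from one core to the other, the change therefore reads alike in this series, but since each step lies within the scatter on its own, the pair shows only that the change left no readable mark on either core, not that it moves the read-out in any direction.

The compounds shown leave open whether another group on the same saturated chain carbon, such as an amine, a carboxylic acid or a longer chain, would read any differently from (nitrooxy)methyl. They also leave open whether the agreement would hold on a third core or at another dose, as two cores tested at a single oral dose cannot settle either question.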